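Fluoro to Trifluoromethyl: Expected Tolerance of Compound 4

The source may report more compounds than this note shows. Statements on the series, on what has been measured and on what is new or still open speak of the compounds shown alone.

Measured compounds:
- compound 1, `COc1ccc(C(C)(C)NC(=O)c2ccc([N+](=O)[O-])o2)cc1`: 82000 nM
- compound 2, `CC(C)(C)c1ccc(C(C)(C)NC(=O)c2ccc([N+](=O)[O-])o2)cc1`: a limit of the assay, > 150000 nM
- compound 3, `CC(C)(NC(=O)c1ccc([N+](=O)[O-])o1)c1ccc(F)cc1`: 42000 nM

In an ADME assay on Vero cells (Chlorocebus sabaeus) for cytotoxicity, read by MTT assay, with a stated time of 48 h (a lower number here means that less compound is tolerated, a higher number that more compound is tolerated), compound 1 gives 82000 nM. Compound 2 reaches only a limit of the assay, > 150000 nM (the limit of > 150000 nM in this assay, at which 1 of the 3 values shown sits). Compound 3 gives 42000 nM, the lower of the two plain numbers; its nearest neighbour is compound 1, and that gap, a 2.0-fold lower number from compound 1 to compound 3 (0.29 log units; within the scatter), is within the scatter.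

Compound 4, `CC(C)(NC(=O)c1ccc([N+](=O)[O-])o1)c1ccc(C(F)(F)F)cc1`, differs from compound 3 in one place: trifluoromethyl in place of fluoro on an aromatic carbon. The measured steps that bear on this change are an at least 3.5-fold lower number from compound 2 to compound 3 (0.55 log units; beyond the scatter) and an at least 1.8-fold higher number from compound 1 to compound 2 (0.26 log units; that floor lies within the scatter): moving away from fluoro toward a larger carbon-rich group at this position went with a higher number in this assay. The same direction is expected here, with a step of a 2.1-fold higher number from compound 3 to compound 4 (0.33 log units; beyond the scatter), possibly reaching the limit again. Compound 4 is therefore estimated at 90000 nM, in a range from 40000 nM to 200000 nM.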

Compound 4, half-maximal cytotoxic concentration: > 150000 nM
Compound 4 was reported as a limit; the forecaster's own chance of this, stated with the estimate: 30%; middle value at least 1.6-fold (0.22 log units) from the limit.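

Trifluoromethyl in place of fluoro on this aromatic carbon gives, in this assay, an at least 3.5-fold higher number from compound 3 to compound 4 (0.55 log units; beyond the scatter), so compound 3 now stands apart, beyond the scatter, from both its tert-butyl and its trifluoromethyl relatives rather than from one alone. Compound 4 gives a limit of the assay, not a number, and it is the second compound to do so: the limit of > 150000 nM in this assay, at which 2 of the 4 values shown sit. Against methoxy, the same group gives an at least 1.8-fold higher number from compound 1 to compound 4 (0.26 log units; that floor lies within the scatter), a floor that does not clear the scatter, and the step between the two compounds at the limit cannot be read.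

This leaves tert-butyl and trifluoromethyl with no order between them. Where a nitrile, an amine or a carboxylic acid on this aromatic carbon would fall in this assay also stays open.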